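Swapping the Butyl Ester for a Pyridine Ester

The compounds below may be only part of what the source reports. "The series", "measured", "known", "first", "only" and "open" are said of these compounds alone.

Of the compounds shown here, two of a shared core have been tested in a functional assay on the whole organism (stomach) for inhibition, with Canis familiaris (Canis lupus familiaris) as the target, at a dose of 5 mg/kg by the intravenous route; a higher number here means a stronger effect of the compound at the dose given, a lower number a weaker effect. Compound 1 `COC(=O)Cc1c(C)nc2c(OCc3ccccc3)cccn12` carries a methoxycarbonyl group on a saturated chain carbon bound to an aromatic carbon, and in this assay compound 1 gives 16%. Compound 2 `CCCCC(=O)OCc1c(C)nc2c(OCc3ccccc3)cccn12` carries a (butylcarbonyl)oxy group at that position instead, and in this assay compound 2 gives 96%. Among the measured compounds shown here, the single measured step, a number 80 percentage points higher from compound 1 to compound 2 (beyond the scatter), places compound 2 at the top of the two numbers, with compound 1 as its only neighbour and far below it.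

Compound 3 `Cc1nc2c(OCc3ccccc3)cccn2c1COC(=O)c1cccnc1` is the next compound in the series. Relative to compound 2 it differs as follows: pyridin-3-yl in place of butyl on a carbonyl carbon. For the measured compounds named here, the only measured step changes the ester direction rather than the acyl group on the carbonyl carbon; it does not bear directly on this change and shows only that the ester part can move the number a long way. Going by the values given here, with no closely comparable step, the step from compound 2 to compound 3 is expected to be modest, most likely a small decrease, a number 14 percentage points lower from compound 2 to compound 3 (beyond the scatter). Compound 3 is therefore estimated at 82% in this assay, within a range from 45% to 100%.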

Compound 3, a percentage reported as inhibition, in the whole organism at one dose (the size of the read-out at that dose, not a potency): 88%
Compound 3: middle estimate off by 6 percentage points, on the low side, within the range that was stated.
By their numbers in this assay, from the lowest: compound 1; then compounds 3 and 2 (each within the scatter of the next).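

In this assay, pyridin-3-yl in place of butyl on a carbonyl carbon gives a number 8 percentage points lower from compound 2 to compound 3 (within the scatter), so this position accepts an aromatic ring carrying a nitrogen in place of an open chain with no change beyond the scatter. The step from the methyl ester is a number 72 percentage points higher from compound 1 to compound 3 (beyond the scatter), which stands alongside a number 80 percentage points higher from compound 1 to compound 2 (beyond the scatter) and shows that the high read-out does not depend on butyl alone: both acyl groups attached through the oxygen stand far above compound 1.

Going by these compounds, what remains open is whether an amide in place of the ester, or a carboxylic acid, an amine or a longer chain on the carbonyl carbon, would keep the read-out at this level. The read-outs also come from a single dose, so they give no potency for either acyl compound and cannot show whether a lower dose would separate compound 2 from compound 3. No measurement in hand accounts for any of these differences.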